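This account rests on a few compounds, and the source may have more. Where it says the series, first, only, none or still open, it means among the compounds named here.

Measured so far:
compound 1, `Nc1cc(N)c2nc(-c3ccccc3)c(Oc3ccc(Cl)c(Cl)c3)nc2c1`, a limit: < 100000 nM
compound 2, `Nc1cc(N)c2nc(-c3ccccc3)c(Sc3ccc(Cl)c(Cl)c3)nc2c1`, a limit: < 100000 nM

In a functional assay on PC-3 cells (Homo sapiens) for inhibition, read by sulforhodamine B assay, with a stated time of 48 h (a higher number here means that more compound is tolerated, a lower number that less compound is tolerated), compound 1 gives only a limit, < 100000 nM. Compound 2 likewise gives only a limit in this assay, < 100000 nM. Between them lies a step that the two limits leave unreadable from compound 1 to compound 2; both values sit at the limit of < 100000 nM in this assay, at which 2 of the 2 values shown sit. Compound 3, `Nc1cc(N)c2nc(-c3ccccc3)c(Sc3ccc(F)cc3)nc2c1`, differs from compound 2 by 4-fluorophenyl in place of 3,4-dichlorophenyl on a sulfur. Among the measured compounds shown here, no measured step bears on this change, and compound 2 stands at a limit. Compound 3 is therefore expected to stand near that limit as well, a step that the limit leaves unreadable from compound 2 to compound 3. Compound 3 is estimated at 40000 nM, within 8000 nM to 100000 nM.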

Compound 3, concentration lethal to 50% of the cells: < 100000 nM
Compound 3 ended at the assay's limit; the forecaster's own chance of this, stated with the estimate: 65%; the middle value does not contradict the limit.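

No step among compound 1, compound 2 and compound 3 can be read, since all three give only a limit: the limit of < 100000 nM in this assay, at which 3 of the 3 values shown sit.

The compounds shown leave open where each one truly stands under that limit, and whether either exchange alters the read-out at all.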